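Compound 1 to compound 4: one more methoxy

This account rests on a few compounds, and the source may have more. Where it says the series, first, only, none or still open, it means among the compounds named here.

- compound 1 `COc1ccc(-c2cc(N)c(C(=O)c3cc(OC)c(OC)c(OC)c3)s2)cc1OC` with 72 nM
- compound 2 `COc1cc(C(=O)c2sc(-c3ccsc3)cc2N)cc(OC)c1OC` with 3.7 nM
- compound 3 `COc1cccc(-c2cc(N)c(C(=O)c3cc(OC)c(OC)c(OC)c3)s2)c1` with 36 nM

All three values come from a functional assay on FM3A cells (Mus musculus) for antiproliferative activity (a lower number here means a stronger inhibitor, a higher number a weaker inhibitor), and compound 4 `COc1cc(C(=O)c2sc(-c3cc(OC)c(OC)c(OC)c3)cc2N)cc(OC)c1OC` is still unmeasured. Compound 1 lies within the scatter of compound 3 and clearly apart from compound 2 (a 19-fold lower number from compound 1 to compound 2 (1.29 log units; beyond the scatter)).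

Compound 4 differs from compound 1 in one place (methoxy in place of hydrogen on an aromatic carbon): methoxy in place of hydrogen on an aromatic carbon, ortho to a methoxy group, meta to a large group and meta to a methoxy group.

The closest evidence is the same kind of change run the other way, hydrogen in place of methoxy on an aromatic carbon (a 2.0-fold lower number from compound 1 to compound 3 (0.30 log units; within the scatter)). This is a single step, so the support is thin. The other two steps (a 19-fold lower number from compound 1 to compound 2 (1.29 log units; beyond the scatter) and a 9.7-fold higher number from compound 2 to compound 3 (0.99 log units; beyond the scatter)) exchange a whole aromatic group for thiophen-3-yl, and they say little about one methoxy.

No step beyond the scatter is therefore expected in this assay, with at most a slight lean to a higher number. The expected step is a 1.4-fold higher number from compound 1 to compound 4 (0.14 log units; within the scatter) on this estimate. For compound 4 the estimated value is 100 nM with an expected range from 35 nM to 300 nM in this assay.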

Compound 4, half-maximal inhibitory concentration: 3500 nM
Estimate against measurement, compound 4: 35-fold (1.54 log units) below; measured number above the stated range.
By their numbers in this assay, from the lowest: compound 2; then compounds 3 and 1 (each within the scatter of the next); then compound 4.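

In this assay, the step of a 49-fold higher number from compound 1 to compound 4 (1.69 log units; beyond the scatter) shows that a methoxy at this place, ortho to a methoxy group, meta to a large group and meta to a methoxy group, is far from a neutral addition to the aromatic ring. Among these compounds, the only earlier methoxy change on this ring, at a different carbon, is a 2.0-fold lower number from compound 1 to compound 3 (0.30 log units; within the scatter) and stays within the scatter, so the response to a methoxy on this ring depends on which carbon carries it, at least across these two steps. Nothing at hand gives a reason for the size of the new step.

From the compounds shown here alone, it remains open whether the high number in compound 4 is specific to methoxy at this carbon or would recur with a fluorine atom, a hydroxy group or an ethoxy group there. Going by these compounds, it also remains open whether this methoxy would give a step of similar size in a compound lacking the methoxy group ortho to it, and whether the step would carry over to other cell assays.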